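2,4-Disubstituted quinazoline series: amino to hydroxy exchange

A few compounds are considered here, and "the series" means these few. Any claim that something is new, unique, unknown or untested is made for them only; others in the source may bear on it.

Measured compounds in an assay for inhibition of Dihydrofolate reductase (Homo sapiens); on this read-out lower numbers stand for lower potency and higher numbers for higher potency (the scale is a negative logarithm):
compound 1 `Nc1nc(N)c2cc(Sc3ccc(Cl)c(Cl)c3)ccc2n1`: 7.96
compound 2 `Nc1nc(O)c2cc([S+]([O-])c3ccc4ccccc4c3)ccc2n1`: 7.38
compound 3 `CCOC(=O)CC[C@H](NC(=O)c1ccc(CNc2ccc3nc(N)nc(O)c3c2)cc1)C(=O)OCC`: 6.24

Compound 1 holds the highest of the three numbers. Compound 2 is nearest, and its value stands beyond the scatter below compound 1. Compound 3 lies furthest away, also beyond the scatter. No two of these compounds differ in a single place, so no step between measured compounds can be stated; what can be said is that both compounds carrying a hydroxy on the shared core sit below compound 1, which carries an amino there.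

Compound 4 `Nc1nc(O)c2cc(Sc3ccc(Cl)c(Cl)c3)ccc2n1` has not been measured. It differs from compound 1 by one change: hydroxy in place of amino on an aromatic carbon. Going by the values given here, the change is at the same place that separates the hydroxy compounds 2 and 3 from compound 1, although the other parts of those molecules also differ, so no direct step is available.

For this assay, a step downward beyond the scatter is expected from compound 1 to compound 4 a number 1.36 log units lower from compound 1 to compound 4 (beyond the scatter). Compound 4 is estimated at 6.6 with a range from 5.7 to 7.5.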

Compound 4, logarithm of the reciprocal of the active concentration, log(1/C): 6.92
Compound 4: the middle estimate sits 0.32 log units below what was measured; measured number inside the range.
By their numbers in this assay, from the lowest: compound 3; then compound 4; then compound 2; then compound 1.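

With the rest of compound 1 unchanged in this assay, hydroxy in place of amino gives a number 1.04 log units lower from compound 1 to compound 4 (beyond the scatter), so this single exchange on the shared core carries a large loss on its own. Compound 2 and compound 3 could only hint at this, as both also differ from compound 1 in other parts; the matched pair now ties the drop to this position, while compound 4 still gives 6.92. No measurement shown bears on the origin of this step.

Whether a step of this size carries over to the other parts seen in compound 2 and compound 3 stays open, as no amino partner of either is among the compounds shown. Also open, as far as these compounds go, is how methoxy, methyl or a plain hydrogen at this place would compare with amino and hydroxy.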